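Swapping a Bromopyridine for an Aminobenzoyl Group

The source may report more compounds than this note shows. Statements on the series, on what has been measured and on what is new or still open speak of the compounds shown alone.

Of the compounds shown here, three have been tested in a functional assay on L5178Y cells (Mus musculus) for inhibition, read by MTT assay, with a stated time of 24 h; a higher number here means a weaker inhibitor, a lower number a stronger inhibitor. Compound 1 `COc1cc(O)c2c(c1)O[C@H](c1ccc(O)cc1)C/C2=N\Nc1ccc(Br)cn1` gives 4300 nM. Compound 2 `COc1cc(O)c2c(c1)O[C@H](c1ccc(O)cc1)C/C2=N\NC(=O)c1ccc(N)cc1` differs from compound 1 by (4-aminophenyl)carbonyl in place of 5-bromopyridin-2-yl on an amine nitrogen. In this assay compound 2 reaches only a limit of the assay, >= 11300 nM (the limit of >= 11300 nM in this assay, at which 1 of the 3 values shown sits). That change produced an at least 2.6-fold higher number from compound 1 to compound 2 (0.41 log units; beyond the scatter). Compound 3 `COc1ccc([C@@H]2C/C(=N\Nc3ccc(Br)cn3)c3c(O)cc(OC)cc3O2)cc1` has a core that differs from that of compound 1 by methyl in place of hydrogen on an oxygen on an aromatic ring; in this assay compound 3 gives 8000 nM, which amounts to a 1.9-fold higher number from compound 1 to compound 3 (0.27 log units; within the scatter). Compound 4 `COc1ccc([C@@H]2C/C(=N\NC(=O)c3ccc(N)cc3)c3c(O)cc(OC)cc3O2)cc1` has not yet been measured. It stands to compound 3 as compound 2 stands to compound 1, the difference being ((4-aminophenyl)carbonyl in place of 5-bromopyridin-2-yl on an amine nitrogen), at the same place in both pairs, so it is the same change made on the second core. The step is expected to be a 3.1-fold higher number from compound 3 to compound 4 (0.49 log units; beyond the scatter), resting on an at least 2.6-fold higher number from compound 1 to compound 2 (0.41 log units; beyond the scatter), which only set a floor for the size of the loss. Compound 4 is therefore expected to give about 25000 nM, most likely between 10000 nM and 60000 nM, and quite possibly only a limit of the assay.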

Compound 4, half-maximal inhibitory concentration: 3900 nM
For compound 4 the middle estimate is 6.4-fold (0.81 log units) above the measured one, outside the stated range (below it).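

In this assay, putting (4-aminophenyl)carbonyl in place of 5-bromopyridin-2-yl on the second core gives a 2.1-fold lower number from compound 3 to compound 4 (0.31 log units; beyond the scatter), so the change does not carry over from one core to the other, and its effect on the two cores runs in opposite directions: the same change on two cores in this assay, an at least 2.6-fold higher number (0.41 log units; beyond the scatter) from compound 1 to compound 2 and a 2.1-fold lower number (0.31 log units; beyond the scatter) from compound 3 to compound 4, at least 5.3-fold (0.73 log units) apart, beyond the scatter of two such steps

Read the other way round, adding the methyl on the oxygen gives an at least 2.8-fold lower number from compound 2 to compound 4 (0.46 log units; beyond the scatter), and this too fails to match the same change made on compound 1: the same change on two cores in this assay, a 1.9-fold higher number (0.27 log units; within the scatter) from compound 1 to compound 3 and an at least 2.8-fold lower number (0.46 log units; beyond the scatter) from compound 2 to compound 4, at least 5.3-fold (0.73 log units) apart, beyond the scatter of two such steps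

Compound 2 reaches only a limit of the assay, so the two gaps have a known minimum but no known size, and these four compounds show that the two changes depend on each other without showing why: the limit of >= 11300 nM in this assay, at which 1 of the 4 values shown sits.

As far as these compounds go, it remains open whether this reversal would also appear with a simple acetyl group on the amine nitrogen, or with an ethyl group in place of the methyl on the oxygen. Four compounds on two cores cannot say how general it is.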